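The source may report more compounds than this note shows. Statements on the series, on what has been measured and on what is new or still open speak of the compounds shown alone.

In an ADME assay on Caco-2 cells (Homo sapiens) for permeability, in the apical to basolateral direction (on this read-out higher numbers stand for higher permeability and lower numbers for lower permeability), compound 1 `CCC(=O)N1CCC(CN(C2Cc3cc(C#N)ccc3N(Cc3cncn3C)C2)S(=O)(=O)c2ccccn2)CC1` gives 0.5 10^-6 cm/s, the lowest of the three numbers recorded here. Compound 2 `Cn1cncc1CN1CC(N(CC2CCN(C(=O)OC(C)(C)C)CC2)S(=O)(=O)c2ccccn2)Cc2cc(C#N)ccc21` gives 15.5 10^-6 cm/s, and compound 3 `Cn1cncc1CN1CC(N(CC2CCN(C(=O)Nc3ccc(Br)cc3)CC2)S(=O)(=O)c2ccccn2)Cc2cc(C#N)ccc21` gives 0.6 10^-6 cm/s. The steps run a 31-fold higher number from compound 1 to compound 2 (1.49 log units; beyond the scatter) and a 1.2-fold higher number from compound 1 to compound 3 (0.08 log units; within the scatter), while a 26-fold lower number from compound 2 to compound 3 (1.41 log units; beyond the scatter). Compound 4 `Cn1cncc1CN1CC(N(Cc2ccc(S(C)(=O)=O)cc2)S(=O)(=O)c2ccccn2)Cc2cc(C#N)ccc21` differs from compound 1 as follows: 4-(methylsulfonyl)phenyl in place of 1-propanoylpiperidin-4-yl on a saturated chain carbon bound to a sulfonamide nitrogen. Among the measured compounds shown here, none of the measured steps touches this place; all three vary the group on a carbonyl carbon, so they bear on compound 4 only loosely, showing that the shared core admits both low and high numbers. A moderate rise is expected, a 4.0-fold higher number from compound 1 to compound 4 (0.60 log units; beyond the scatter), with wide uncertainty. Compound 4 is therefore estimated at 2 10^-6 cm/s, within 0.5 10^-6 cm/s to 8 10^-6 cm/s.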

Compound 4, apparent permeability: 0.2 10^-6 cm/s
The estimate for compound 4 lay 10-fold (1.00 log units) above the measured number; the whole stated range lies above it.
By their numbers in this assay, from the lowest: compound 4; then compounds 1 and 3 (each within the scatter of the next); then compound 2.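

In this assay putting 4-(methylsulfonyl)phenyl in place of 1-propanoylpiperidin-4-yl on a saturated chain carbon bound to a sulfonamide nitrogen gives a 2.5-fold lower number from compound 1 to compound 4 (0.40 log units; beyond the scatter) as a modest step. Among the compounds shown here, this place, which no earlier step touched, therefore also moves the number, and here the aromatic ring of carbon only does not raise it. Nothing available accounts for this step. Still open, from the compounds shown here alone, is whether the methylsulfonyl group or the phenyl ring carries the step, and how an amine or a carboxylic acid on that ring would read.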